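Swapping the aryl group on the sulfur bridge

A few compounds are considered here, and "the series" means these few. Any claim that something is new, unique, unknown or untested is made for them only; others in the source may bear on it.

Compound 2 `Nc1cc(N)c2nc(-c3ccccc3)c(Sc3ccc(Cl)c(Cl)c3)nc2c1` carries a (3,4-dichlorophenyl)sulfanyl group on an aromatic carbon of the shared core. In a functional assay on NCI/ADR-RES cells (Homo sapiens) for inhibition, read by sulforhodamine B assay, with a stated time of 48 h (on this read-out higher numbers stand for lower toxicity in this test and lower numbers for higher toxicity in this test), compound 2 gives only a limit, < 100000 nM, not a measured number. Compound 1 `Nc1cc(N)c2nc(-c3ccccc3)c(NCc3ccc(F)cc3)nc2c1`, which has a (4-fluorobenzyl)amino group at that same carbon instead, reaches 28200 nM in this assay. The step that the limit leaves unreadable from compound 1 to compound 2 cannot be read, since the value of compound 2 sits at the limit (the limit of < 100000 nM in this assay, at which 1 of the 2 values shown sits). The unmeasured compound 3 `Nc1cc(N)c2nc(-c3ccccc3)c(Sc3ccc(F)cc3)nc2c1` differs from compound 2 by 4-fluorophenyl in place of 3,4-dichlorophenyl on a sulfur. Within the data shown here, none of the measured steps touches the group on the sulfur, so no step size can be carried over to this change; the only firm anchor in this assay is compound 1 at 28200 nM. Compound 3 is therefore expected, with wide uncertainty, at 40000 nM, between 8000 nM and 100000 nM, a step that the limit leaves unreadable from compound 2 to compound 3 that cannot be sized against a limit.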

Compound 3, concentration lethal to 50% of the cells: 72400 nM
Compound 3: middle estimate off by 1.8-fold (0.26 log units), on the low side; measured number inside the range.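

With compound 3, a sulfur-linked aryl group on this aromatic carbon has a measured number in this assay, so the two kinds of group at this carbon can now be compared: replacing (4-fluorobenzyl)amino with (4-fluorophenyl)sulfanyl gives a 2.6-fold higher number from compound 1 to compound 3 (0.41 log units; beyond the scatter). On this read-out, that modest step means lower toxicity for the sulfur-linked compound of this one pair. Compound 2 gives only a limit, and its steps cannot be read because of that: the limit of < 100000 nM in this assay, at which 1 of the 3 values shown sits.

This single readable step changes the link and the group attached to it together, so it cannot say which of the two matters. As far as these compounds go, how a 4-fluorobenzyl group on the sulfur, or an unsubstituted phenyl or a longer alkyl chain there, would read remains open.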